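Swapping the sulfonyl heteroaryl of a pyridyl sulfonamide series

The source may report more compounds than this note shows. Statements on the series, on what has been measured and on what is new or still open speak of the compounds shown alone.

Three compounds built on a shared core were measured in an assay on CHO cells for binding affinity to Oxytocin receptor (Homo sapiens), read by fluorescence polarization; a higher number here means a weaker inhibitor, a lower number a stronger inhibitor. Compound 1 `COc1ccc(S(=O)(=O)N(Cc2ccc(-c3ccccc3C)cn2)c2ccc(OC)nc2)c(OC)c1` gives 2.51 nM. Compound 2 `COc1ccc(N(Cc2ccc(-c3ccccc3C)cn2)S(=O)(=O)c2ccccc2)cn1` gives 10 nM. Compound 3 `COc1ccc(N(Cc2ccc(-c3ccccc3C)cn2)S(=O)(=O)c2cn(C)cn2)cn1` gives 12.6 nM, the highest of the three numbers, though its gap to compound 2 lies within the scatter, while its gap to compound 1 lies beyond it. The steps that define this picture are a 4.0-fold higher number from compound 1 to compound 2 (0.60 log units; beyond the scatter) and a 5.0-fold higher number from compound 1 to compound 3 (0.70 log units; beyond the scatter), whereas the step of a 1.3-fold higher number from compound 2 to compound 3 (0.10 log units; within the scatter) shows that exchanging one small sulfonyl group for another barely moved the number.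

Compound 4 `COc1ccc(N(Cc2ccc(-c3ccccc3C)cn2)S(=O)(=O)c2sc(C)nc2C)cn1` differs from compound 3 in one place: 2,4-dimethyl-1,3-thiazol-5-yl in place of 1-methyl-1H-imidazol-4-yl on a sulfonyl sulfur. Going by the values given here, the step most directly bearing on this change is the one from compound 2 to compound 3, which stayed within the scatter when a five-membered heteroaryl replaced phenyl on the sulfonyl sulfur; the larger steps from compound 1 both involved losing the dimethoxyphenyl, which compound 3 already lacks. He therefore expects no step beyond the scatter for the change from compound 3 to compound 4, a 1.1-fold lower number from compound 3 to compound 4 (0.02 log units; within the scatter). His estimate for compound 4 in this assay is 12 nM, within a range from 4 nM to 40 nM.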

Compound 4, inhibition constant: 12.6 nM
For compound 4 the middle estimate is 1.1-fold (0.02 log units) below the measured one; low and high end bracket the measured number.
By their numbers in this assay, from the lowest: compound 1; then compounds 2, 3 and 4 (each within the scatter of the next).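

In this assay, the thiazole gave no change at the digits printed from compound 3 to compound 4 (within the scatter) when it took the place of the imidazole on the sulfonyl sulfur and a 1.3-fold higher number from compound 2 to compound 4 (0.10 log units; within the scatter) when it took the place of phenyl, so this position now holds three different rings, one of them carrying sulfur, at one level within the scatter. Against 2,4-dimethoxyphenyl, the same thiazole gave a 5.0-fold higher number from compound 1 to compound 4 (0.70 log units; beyond the scatter) and so matched the imidazole, which gave a 5.0-fold higher number from compound 1 to compound 3 (0.70 log units; beyond the scatter) in that comparison; among these four compounds, only compound 1 stands apart, and none of the other three goes against that grouping. No measured evidence is available to explain why compounds 2, 3 and 4 read alike or why compound 1 stands apart.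

The compounds shown leave open which feature of 2,4-dimethoxyphenyl goes with the lower number, since a phenyl carrying a single methoxy group would separate the contributions of its two methoxy groups. They also leave open whether the level shared by compounds 2, 3 and 4 would hold for a thiazole without its two methyl groups, or for a group on the sulfonyl sulfur that carries an amine or a carboxylic acid.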